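Oxime to Acetyl on the Anilide Arm: an Expected Loss

The compounds below may be only part of what the source reports. "The series", "measured", "known", "first", "only" and "open" are said of these compounds alone.

Measured so far:
Compound 1, `C=CCn1c(SCC(=O)Nc2ccc(C(C)=O)cc2)nnc1-c1ccccc1`: 48%
Compound 2, `C=CCn1c(SCC(=O)Nc2ccc(/C(C)=N/O)cc2)nnc1-c1ccccc1`: 61%
Compound 3, `C=CCn1c(SCC(=O)Nc2ccc(/C(C)=N/O)cc2)nnc1-c1ccc(OC)cc1`: 54%

All three were tested in a functional assay on the whole organism (strain albino) for inhibition, with Rattus norvegicus as the target, read by paw edema, with stated times of 30 min and 1 h, at a dose of 0.28 mmol/kg by the oral route; on this read-out higher numbers stand for more inhibition at the one dose given (going by the name of the read-out) and lower numbers for less inhibition. Compound 1 differs from compound 2 by a group of 3 heavy atoms (2 carbon, 1 oxygen; no ring) in place of a group of 4 heavy atoms (2 carbon, 1 nitrogen, 1 oxygen; no ring), on an aromatic carbon; in this assay that change gave a number 13 percentage points lower from compound 2 to compound 1 (beyond the scatter). Compound 3 differs from compound 2 in its core by methoxy in place of hydrogen on an aromatic carbon, and that change gave a number 7 percentage points lower from compound 2 to compound 3 (within the scatter), so compound 2 and compound 3 cannot be told apart here.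

Compound 4, `C=CCn1c(SCC(=O)Nc2ccc(C(C)=O)cc2)nnc1-c1ccc(OC)cc1`, has not been measured. It differs from compound 3 by a group of 3 heavy atoms (2 carbon, 1 oxygen; no ring) in place of a group of 4 heavy atoms (2 carbon, 1 nitrogen, 1 oxygen; no ring), on an aromatic carbon. The place of this change is the same, word for word, as the place of the change from compound 2 to compound 1, so it is the same change made on the core of compound 3 instead of the core of compound 2. This change has been seen once before among these compounds, where it was measured as a number 13 percentage points lower from compound 2 to compound 1 (beyond the scatter). The step for compound 4 is therefore expected to be a number 13 percentage points lower from compound 3 to compound 4 (beyond the scatter), resting on that earlier step because a number 13 percentage points lower from compound 2 to compound 1 (beyond the scatter) was measured for the same change, and the cores differ only by methoxy in place of hydrogen on an aromatic carbon. Compound 4 is thus estimated to give 41%, with a likely range from 30% to 52%.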

Compound 4, a percentage reported as inhibition, in the whole organism at one dose (the size of the read-out at that dose, not a potency): 50%
Estimate against measurement, compound 4: 9 percentage points below; the range from low to high includes it.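

In this assay, putting acetyl in place of the oxime group on the methoxy-bearing core gave a number 4 percentage points lower from compound 3 to compound 4 (within the scatter), and this step cannot be told apart from the one seen on the first core: the same change on two cores in this assay, a number 13 percentage points lower (beyond the scatter) from compound 2 to compound 1 and a number 4 percentage points lower (within the scatter) from compound 3 to compound 4, 9 percentage points apart, within the scatter of two such steps Methoxy in place of hydrogen on the acetyl compounds gave a number 2 percentage points higher from compound 1 to compound 4 (within the scatter), and this step also agrees with its counterpart on the oxime compounds: the same change on two cores in this assay, a number 7 percentage points lower (within the scatter) from compound 2 to compound 3 and a number 2 percentage points higher (within the scatter) from compound 1 to compound 4, 9 percentage points apart, within the scatter of two such steps The two cores therefore give no sign that the change behaves differently from one to the other, but two pairs cannot show that it carries over by a fixed amount, and on the core of compound 3 the step alone cannot be told from no change.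

Only acetyl and the oxime group are compared at this place, and only hydrogen and methoxy at the other. As far as these compounds go, what an amine, a carboxylic acid or a longer chain would do at the acetyl position remains open, as does whether any such group would follow the same pattern on both cores.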